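A Ring Enters the Amide Side Chain

This account rests on a few compounds, and the source may have more. Where it says the series, first, only, none or still open, it means among the compounds named here.

In a functional assay on PANC-1 cells (Homo sapiens) for antiproliferative activity, read by MTT assay, with a stated time of 48 h (on this read-out lower numbers stand for stronger inhibition and higher numbers for weaker inhibition), compound 1 (`Cc1ccc(NC(=O)c2oc3ccc(N(Cc4ccc(Br)cc4)S(=O)(=O)c4ccc(Br)cc4)cc3c2C)nc1`) gives > 40000 nM, which is a limit of the assay and not a number. Compound 2 (`CN(C)CCNC(=O)c1nc2cc(N(Cc3ccc(Br)cc3)S(=O)(=O)c3ccc(Br)cc3)ccc2o1`) gives 13600 nM, and compound 3 (`CCN(CC)CCNC(=O)c1nc2cc(N(Cc3ccc(Br)cc3)S(=O)(=O)c3ccc(Br)cc3)ccc2o1`) gives 12600 nM. These two numbers lie within the scatter of each other, so compound 3 stands level with compound 2. Compound 4 (`CN1CCC(NC(=O)c2nc3cc(N(Cc4ccc(Br)cc4)S(=O)(=O)c4ccc(Br)cc4)ccc3o2)CC1`) has not yet been measured. It carries 1-methylpiperidin-4-yl in place of 2-(diethylamino)ethyl on an amide-type nitrogen. Among the measured compounds shown here, the one measured step that bears on this is a 1.1-fold lower number from compound 2 to compound 3 (0.03 log units; within the scatter), with diethylamino in place of dimethylamino, and it lies within the scatter. For the measured compounds named here, that step brings in no ring, so it is only a partial guide, and no other measured step tests this kind of replacement. No step beyond the scatter is therefore expected in this assay, although the range is kept wide. The expected step is a 1.1-fold lower number from compound 3 to compound 4 (0.02 log units; within the scatter). For compound 4 the estimated value is 12000 nM, with an expected range from 5000 nM to 30000 nM.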

Compound 4, half-maximal inhibitory concentration: 5910 nM
Compound 4: the middle estimate sits 2.0-fold (0.31 log units) above what was measured; the range from low to high includes it.
By their numbers in this assay, from the lowest: compound 4; then compounds 3 and 2 (each within the scatter of the next). At a limit, above all of these: compound 1.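

On the amide-type nitrogen, 1-methylpiperidin-4-yl gives the only steps beyond the scatter among these side chains in this assay: a 2.1-fold lower number from compound 3 to compound 4 (0.33 log units; beyond the scatter), and a 2.3-fold lower number from compound 2 to compound 4 (0.36 log units; beyond the scatter). The leaving 2-(diethylamino)ethyl and the entering 1-methylpiperidin-4-yl have the same heavy-atom count, so this step comes with a six-membered non-aromatic ring and not with added atoms. Nothing measured here gives a reason for the step.

The compounds shown leave open whether the ring nitrogen needs its methyl group, as a piperidine without it or a 1-ethylpiperidine would show, and whether a morpholine or pyrrolidine ring would serve as well. Going by these compounds, it also stays open whether the ring must sit directly on the amide-type nitrogen, or whether an ethyl chain leading to a piperidine would give the same result.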